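The source may report more compounds than this note shows. Statements on the series, on what has been measured and on what is new or still open speak of the compounds shown alone.

For the measured compounds named here, compound 1 `C=CC(=O)Nc1cccc(Nc2ncnc(Nc3ccc(C(=O)N4CCCCC4)cc3)n2)c1` is the only member of this series with a number: in a functional assay on Ramos cells (Homo sapiens) for antiproliferative activity, read by CCK-8 assay, with a stated time of 24 h (on this read-out higher numbers stand for weaker inhibition and lower numbers for stronger inhibition), compound 1 gives 6140 nM. Compound 2 `C=CC(=O)Nc1cccc(Nc2ncnc(Nc3ccc(-c4ccc(C)nc4)cc3)n2)c1` has no result in this assay: for compound 2 the entry is "not determined" (no result reported), so it stands nowhere on the numbers shown. Compound 3 `C=CC(=O)Nc1cccc(Nc2ncnc(Nc3ccc(C(=O)Nc4ccc(C)cn4)cc3)n2)c1` keeps the shared core of compound 2 and differs from it by (5-methylpyridin-2-yl)carbamoyl in place of 6-methylpyridin-3-yl on an aromatic carbon. Going by the values given here, with no measured pair to anchor this change, the step from compound 2 to compound 3 in this assay is expected to stay within the scatter, with no direction favoured. Compound 3 is estimated at 4000 nM, within a range from 600 nM to 25000 nM.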

Compound 3, half-maximal inhibitory concentration: > 100000 nM
Compound 3 gave a limit, no number; the forecaster's own chance of this, stated with the estimate: 15%; at least 25-fold (1.39 log units) between middle value and limit.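

In this assay, (5-methylpyridin-2-yl)amino in place of piperidin-1-yl on the carbonyl carbon gives an at least 16-fold higher number from compound 1 to compound 3 (1.21 log units; beyond the scatter), so the read-out at this position depends on the group the carbonyl carries. The step from compound 2 to compound 3 cannot be read. The entry for compound 3 is a limit of the assay, not a number: the limit of > 100000 nM in this assay, at which 1 of the 3 values shown sits.

Still open, as far as these compounds go, is how morpholin-4-yl or dimethylamino on the same carbonyl carbon would read. Also open, from the compounds shown here alone, is whether any group there gives a lower number than compound 1.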